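The compounds below may be only part of what the source reports. "The series", "measured", "known", "first", "only" and "open" are said of these compounds alone.

Compounds measured in a functional assay on HCC827 cells (Homo sapiens) for antiproliferative activity, read by MTT assay, with a stated time of 72 h; a lower number here means a stronger inhibitor, a higher number a weaker inhibitor:
compound 1 `CNC(=O)CN1CC[C@H](n2c(Nc3ccccc3)nc3cnc(Nc4ccc(N5CCN(C)CC5)cc4)nc32)C1`, 170 nM
compound 2 `CN1CCN(c2ccc(Nc3ncc4nc(Nc5ccc(F)cc5)n([C@H]5CCCN(S(=O)(=O)C6CC6)C5)c4n3)cc2)CC1`, 8.6 nM
compound 3 `CN1CCN(c2ccc(Nc3ncc4nc(Nc5ccccc5)n([C@@H]5CCN(C(=O)OC(C)(C)C)C5)c4n3)cc2)CC1`, 12 nM

Compound 2 gives the lowest number of the three; compound 3 lies within the scatter of it, while compound 1 stands well beyond. Compound 4 `CN1CCN(c2ccc(Nc3ncc4nc(Nc5ccc(F)cc5)n([C@H]5CCN(C(=O)CO)C5)c4n3)cc2)CC1` is not yet measured. Relative to compound 2 the change is 1-((hydroxymethyl)carbonyl)pyrrolidin-3-yl in place of 1-(cyclopropylsulfonyl)piperidin-3-yl on an aromatic nitrogen. Going by the values given here, the only measured step touching this part of the molecule is a 14-fold lower number from compound 1 to compound 3 (1.15 log units; beyond the scatter), a large one, showing that the group on the ring nitrogen can shift the number strongly. Compound 2 and compound 3 carry different rings and different groups there, yet sit within the scatter of each other. For compound 4 only a small step is expected, a 1.7-fold higher number from compound 2 to compound 4 (0.24 log units; within the scatter), a slight weakening if any. Compound 4 is estimated at 15 nM, range 5 nM to 50 nM.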

Compound 4, half-maximal inhibitory concentration: 380 nM
For compound 4 the middle estimate is 25-fold (1.40 log units) below the measured one; measured number above the stated range.
By their numbers in this assay, from the lowest: compounds 2 and 3 (each within the scatter of the next); then compound 1; then compound 4.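

At this aromatic nitrogen, the change gives a 44-fold higher number from compound 2 to compound 4 (1.65 log units; beyond the scatter) in this assay, so the position does not accept every replacement; the earlier large step ran toward a lower number, and this one runs the other way. Ring size, the group on the ring nitrogen and the hydrogen-bond donor count all change together, and the step cannot be assigned to any one of them. No measurement at hand accounts for the loss. Which part carries it stays open: a methoxyacetyl group on the pyrrolidine, or a hydroxyacetyl group on the piperidine, would separate them.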